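Swapping an Aromatic Substituent and Its Effect on Tolerance

The source may report more compounds than this note shows. Statements on the series, on what has been measured and on what is new or still open speak of the compounds shown alone.

Compound 1 `CC(CCNC(=O)c1c(Cl)cncc1Cl)N1CCC(C(Oc2ccc(C(F)(F)F)cc2)c2ccc(C(F)(F)F)cc2)CC1` was tested in an ADME assay on PBMC cells (Homo sapiens) for cytotoxicity (a higher number here means that more compound is tolerated, a lower number that less compound is tolerated), and gives 3100 nM, the lowest of the three numbers at hand. Compound 2 `CC(CCNC(=O)c1c(Cl)cncc1Cl)N1CCC(C(Oc2cccnc2)c2ccc(Br)cc2)CC1` gives 32500 nM in this assay, and compound 3 `CCO/N=C(/c1ccc(Br)cc1)C1CCN(C2(CCNC(=O)c3c(Cl)cncc3Cl)CC2)CC1` gives 33000 nM; both of these lie beyond the usual scatter above compound 1, so compound 1 is the least tolerated of the three. Compound 4 `CC(CCNC(=O)c1c(Cl)cncc1Cl)N1CCC(C(Oc2ccccc2C#N)c2ccc(C(F)(F)F)cc2)CC1` has not yet been measured. It differs from compound 1 in one place: 2-cyanophenyl in place of 4-(trifluoromethyl)phenyl on an oxygen on a saturated carbon. Among the compounds with values here, no pair of measured compounds is separated by just this change, so its effect can only be guessed. Compound 2, which also carries a different group on that oxygen, shows a higher number than compound 1, which hints that replacing this group may let more compound be tolerated. For compound 4 a modest upward step is expected in this assay, namely a 2.3-fold higher number from compound 1 to compound 4 (0.35 log units; beyond the scatter). For compound 4 the estimated value is 7000 nM, within a range from 2500 nM to 20000 nM.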

Compound 4, half-maximal cytotoxic concentration: 17000 nM
Compound 4: the middle estimate sits 2.4-fold (0.39 log units) below what was measured; low and high end bracket the measured number.
By their numbers in this assay, from the lowest: compound 1; then compounds 4, 2 and 3 (each within the scatter of the next).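

In this assay, within the data shown here, putting 2-cyanophenyl in place of 4-(trifluoromethyl)phenyl on the oxygen gives a 5.5-fold higher number from compound 1 to compound 4 (0.74 log units; beyond the scatter), and this is the only comparison here in which just one place changes. It shows that the group on this oxygen can, with the rest of compound 1 left as it is, move the tolerated concentration by more than the usual scatter of the measurement. No measurement at hand explains why the number rises with this swap.

Still open, as far as these compounds go, is whether the rise goes with gaining the nitrile, with losing the trifluoromethyl, or with both, as this single step changes them together. A plain phenyl on the same oxygen, or a 4-cyanophenyl there, would help to pull these possibilities apart.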